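Adding a Propyl Chain to an Anilino Quinone

A few compounds are considered here, and "the series" means these few. Any claim that something is new, unique, unknown or untested is made for them only; others in the source may bear on it.

Compound 2 `O=C1C(Nc2ccccc2)=CC(=O)c2c1nc1n2[C@H]2OC[C@@H](O)[C@H]2OC1` carries a phenylamino group on the shared core. In a functional assay on ECa-109 cells for inhibition, with ECa-109 cell line (Homo sapiens) as the target, read by sulforhodamine B assay (a higher number here means a weaker inhibitor, a lower number a stronger inhibitor), compound 2 gives 3560 nM. Among the compounds with values here, this is the only plain number among the three measured compounds; the other two results are limits of the assay rather than numbers. Compound 1 `CCCc1ccc(NC2=CC(=O)c3nc4n(c3C2=O)[C@H]2OC[C@@H](O)[C@H]2OC4)cc1` carries the same 4-propylphenylamino group that compound 4 will carry, but placed as a regioisomer on the core. In this assay compound 1 gives only a limit, > 4000 nM. Compound 3 `CCCN(CCC)C1=CC(=O)c2nc3n(c2C1=O)[C@H]1OC[C@@H](O)[C@H]1OC3`, with a dipropylamino group instead of an arylamino group, also gives only a limit in this assay, > 16000 nM. Within the data shown here, compound 2 therefore stands alone as the one compound with a definite reading, and no measured pair differs in a single place, so no step can be read off directly.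

Compound 4 `CCCc1ccc(NC2=CC(=O)c3c(nc4n3[C@H]3OC[C@@H](O)[C@H]3OC4)C2=O)cc1` is compound 2 with one change: propyl in place of hydrogen on an aromatic carbon. Its regioisomer compound 1 sits at the limit described as the limit of > 4000 nM in this assay, at which 1 of the 3 values shown sits. On that basis a small to moderate step toward weaker inhibition in this assay is expected, with a real chance that the result again comes back only as a limit. The expected step is a 1.7-fold higher number from compound 2 to compound 4 (0.23 log units; within the scatter). Compound 4 is estimated at 6000 nM, within a range from 2500 nM to 15000 nM.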

Compound 4, half-maximal inhibitory concentration: > 4000 nM
Compound 4: no number, only a limit; the forecaster's own chance of this, stated with the estimate: 45%; the middle value lies beyond the limit too.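

In this assay compound 4 gives > 4000 nM, which is a limit of the assay and not a number. Within the data shown here, this is the first comparison here that differs in one place, and swapping phenyl for 4-propylphenyl, with the propyl on an aromatic carbon para to a large group, can be stated only as a floor: the change gives an at least 1.1-fold higher number from compound 2 to compound 4 (0.05 log units; that floor lies within the scatter). Since that floor lies within the usual scatter, the result does not establish that propyl at this position changes the reading at all, although it does show that the true value cannot be placed, and this reading is not alone at that ceiling: the limit of > 4000 nM in this assay, at which 2 of the 4 values shown sit.

As far as these compounds go, it remains open how far the true value of compound 4 lies beyond its limit, and therefore whether the propyl step is negligible or large. A smaller methyl, a longer chain such as butyl, or an amine or a carboxylic acid at the same position would show whether anything placed here moves the reading, and a definite number for any of these would give a step that can be measured in full.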